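A Smaller Group Replaces tert-Butyl on the Urea Aryl Ring

The source may report more compounds than this note shows. Statements on the series, on what has been measured and on what is new or still open speak of the compounds shown alone.

Compound 1 `COc1cc2ncnc(NCc3cccc(NC(=O)Nc4cccc(C)c4)c3)c2cc1OC`: 27100 nM
Compound 2 `COc1ccccc1NC(=O)Nc1cccc(CNc2ncnc3cc(OC)c(OC)cc23)c1`: 15200 nM
Compound 3 `COc1cc2ncnc(NCc3cccc(NC(=O)Nc4ccc(C(C)(C)C)cc4)c3)c2cc1OC`: 5210 nM

Three compounds share a common core and differ only in the aryl group on the urea nitrogen. In a functional assay on A549 cells (Homo sapiens) for antiproliferative activity, read by MTT assay (on this read-out higher numbers stand for weaker inhibition and lower numbers for stronger inhibition), compound 3 stands lowest of the three numbers, as the steps of a 5.2-fold lower number from compound 1 to compound 3 (0.72 log units; beyond the scatter) and a 2.9-fold lower number from compound 2 to compound 3 (0.47 log units; beyond the scatter) show; the step of a 1.8-fold lower number from compound 1 to compound 2 (0.25 log units; within the scatter) stays within the scatter. Compound 4 `COc1cc2ncnc(NCc3cccc(NC(=O)Nc4ccc(F)cc4)c3)c2cc1OC` differs from compound 3 by fluoro in place of tert-butyl on an aromatic carbon. Among the compounds with values here, no measured step exchanges tert-butyl for fluoro directly, so the two steps leading into compound 3 are the only guide: each time the 4-(tert-butyl)phenyl was replaced by a ring bearing a smaller methyl or methoxy group, the number rose. A fluoro group is likewise small, so the step from compound 3 to compound 4 is expected to run upward again, estimated as a 2.9-fold higher number from compound 3 to compound 4 (0.46 log units; beyond the scatter). Compound 4 is therefore expected to give about 15000 nM in this assay, with a likely range from 5000 nM to 45000 nM.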

Compound 4, half-maximal inhibitory concentration: 16900 nM
Compound 4: the middle estimate sits 1.1-fold (0.05 log units) below what was measured; the range from low to high includes it.
By their numbers in this assay, from the lowest: compound 3; then compounds 2, 4 and 1 (each within the scatter of the next).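

In this assay, within the data shown here, exchanging tert-butyl for fluoro gives a 3.2-fold higher number from compound 3 to compound 4 (0.51 log units; beyond the scatter), and this is the first step here that changes the group while leaving its place on the ring the same. The 4-fluorophenyl ring also joins the two other small-substituent rings: a 1.1-fold higher number from compound 2 to compound 4 (0.05 log units; within the scatter) and a 1.6-fold lower number from compound 1 to compound 4 (0.21 log units; within the scatter) both lie within the scatter, so among these four compounds only the 4-(tert-butyl)phenyl ring stands apart. Nothing measured here explains why compound 3 gives the lowest number.

From the compounds shown here alone, with only tert-butyl and fluoro compared at this place, it remains open whether the number follows the size of the group or is particular to tert-butyl. Ethyl or isopropyl at the same place would show whether intermediate groups give intermediate numbers, and an amine or a carboxylic acid there would probe a quite different kind of group.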